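A few compounds are considered here, and "the series" means these few. Any claim that something is new, unique, unknown or untested is made for them only; others in the source may bear on it.

Compound 1 `O=C(/C=C/c1cccc(O)c1)c1cccc(-n2cc(-c3ccccc3)[nH]c2=O)c1`: 12100 nM
Compound 2 `COc1cc(/C=C/C(=O)c2cccc(-n3cc(-c4ccccc4)[nH]c3=O)c2)cc(OC)c1OC`: 4470 nM

In a functional assay on SNB-75 cells (Homo sapiens) for inhibition (on this read-out lower numbers stand for stronger inhibition of growth and higher numbers for weaker inhibition of growth), compound 2 stands lowest of the two measured compounds at 4470 nM, and the gap up to compound 1 lies beyond the scatter. Compound 3 `COc1cc(/C=C/C(=O)c2cccc(-n3cc(-c4cc(OC)c(OC)c(OC)c4)[nH]c3=O)c2)cc(OC)c1OC` has 3,4,5-trimethoxyphenyl in place of phenyl on an aromatic carbon. Among the measured compounds shown here, no measured pair isolates a single change, so this expectation is tentative: a small step toward a lower number in this assay, possibly none beyond the scatter. The expected move is a 1.4-fold lower number from compound 2 to compound 3 (0.15 log units; within the scatter). Compound 3 is estimated at 3200 nM, with an expected range of 1100 nM to 10000 nM.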

Compound 3, concentration for 50% growth inhibition: 5130 nM
Beside the measured number, compound 3's estimate is 1.6-fold (0.20 log units) below it, within the range that was stated.
By their numbers in this assay, from the lowest: compounds 2 and 3 (each within the scatter of the next); then compound 1.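

In this assay, the only pair shown that differs in one place gives a 1.1-fold higher number from compound 2 to compound 3 (0.06 log units; within the scatter). An aromatic carbon of a five-membered aromatic ring with 2 nitrogen therefore carries either the phenyl of 6 heavy atoms or the 3,4,5-trimethoxyphenyl of 12 heavy atoms with no change that can be read in this read-out. Nothing at hand gives a cause for this result. The compounds shown leave open whether an amine or a carboxylic acid on this phenyl ring, in place of the methoxy groups, would move the number beyond the scatter.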